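A few compounds are considered here, and "the series" means these few. Any claim that something is new, unique, unknown or untested is made for them only; others in the source may bear on it.

Measured so far in a functional assay on HEK293 cells for agonist activity at Free fatty acid receptor 1 (Homo sapiens), read by fluorescence and calcium flux, with a stated time of 10 min; a lower number here means that less compound is needed, a higher number that more compound is needed for the effect:
compound 1 `CC#C[C@@H](CC(=O)O)c1ccc(OC[C@H]2COc3ccc(Cl)cc3O2)cc1` gives 50 nM
compound 2 `CC#C[C@H](CC(=O)O)c1ccc(OC[C@H]2COc3ccc(Cl)cc3O2)cc1` gives 3400 nM
compound 3 `CC#C[C@@H](CC(=O)O)c1ccc(OC[C@@H]2COc3ccc(Cl)cc3O2)cc1` gives 260 nM

Compound 1 has the lowest number of the three in this assay; compound 3 is nearest, at a 5.2-fold higher number from compound 1 to compound 3 (0.72 log units; beyond the scatter), and compound 2 furthest, at a 68-fold higher number from compound 1 to compound 2 (1.83 log units; beyond the scatter). Between the other two lies a 13-fold lower number from compound 2 to compound 3 (1.12 log units; beyond the scatter). All three measured steps rest on configuration alone, as shown by the fact that compounds 1 and 2 differ only in the configuration as drawn, the fact that compounds 1 and 3 differ only in the configuration as drawn and (the fact that compounds 2 and 3 differ only in the configuration as drawn).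

Compound 4 `CC#C[C@@H](CC(=O)O)c1ccc(OC[C@H]2COc3ccc(OC(F)(F)F)cc3O2)cc1` keeps the configuration of compound 1 and alters only a ring substituent: trifluoromethoxy in place of chloro on an aromatic carbon. For the measured compounds named here, none of the measured steps touches a substituent on that ring, so they give no direction for this change; the expectation is that compound 4 stays close to compound 1, with a step of no change at the digits printed from compound 1 to compound 4 (within the scatter) not beyond the scatter. For compound 4 the estimate in this assay is 50 nM, range 15 nM to 170 nM.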

Compound 4, half-maximal effective concentration: 700 nM
Compound 4: middle estimate off by 14-fold (1.15 log units), on the low side; measured number outside the range, above it.
By their numbers in this assay, from the lowest: compound 1; then compound 3; then compound 4; then compound 2.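

In this assay, for the compounds shown here, this position on the fused ring system is sensitive to its substituent, which the earlier steps, all confined to configuration, could not show. With the configuration of compound 1 held, trifluoromethoxy in place of chloro gives a 14-fold higher number from compound 1 to compound 4 (1.15 log units; beyond the scatter) and so places compound 4 after compound 3 in the order. Nothing available bears on the cause of this step.

Two substituents cannot separate the contribution of the ether oxygen from that of the fluorines; methoxy and trifluoromethyl at this position would address that. From the compounds shown here alone, whether a smaller fluoro or a larger bromo would match chloro also remains open.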